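Swapping the aryl group on the anilino nitrogen

The source may hold more compounds than are shown below. What is called first, only, known or untested is meant among the compounds shown, and "the series" means these compounds.

Measured so far:
Compound 1, `CCCc1ccc(NC2=CC(=O)c3nc4n(c3C2=O)[C@H]2OC[C@@H](O)[C@H]2OC4)cc1`, gives 1560 nM.
Compound 2, `O=C1C(Nc2ccccc2)=CC(=O)c2c1nc1n2[C@H]2OC[C@@H](O)[C@H]2OC1`, gives 1830 nM.

Both numbers come from a functional assay on MGC-803 cells (Homo sapiens) for inhibition, read by sulforhodamine B assay; on this read-out lower numbers stand for stronger inhibition and higher numbers for weaker inhibition. Compound 1 has the lowest of the two numbers, but its gap to compound 2 lies within the scatter, so the two cannot be told apart. The new compound 3, `CCOc1ccccc1NC1=CC(=O)c2nc3n(c2C1=O)[C@H]1OC[C@@H](O)[C@H]1OC3`, keeps the shared core and changes only the group on the amine nitrogen: 2-ethoxyphenyl in place of 4-propylphenyl on an amine nitrogen. Within the data shown here, no measured pair shows what such a change does here, and compound 1 and compound 2 together suggest that altering this aryl group shifts the read-out little. The step from compound 1 to compound 3 is therefore expected to be small, in no clear direction, and to stay within the scatter: a 1.2-fold higher number from compound 1 to compound 3 (0.06 log units; within the scatter). For compound 3 the expected value is 1800 nM, with a range from 800 nM to 4000 nM.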

Compound 3, half-maximal inhibitory concentration: 2450 nM
Compound 3: the middle estimate sits 1.4-fold (0.13 log units) below what was measured, and the stated range covers the measured number.
By their numbers in this assay, from the lowest: compounds 1, 2 and 3 (each within the scatter of the next).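

In this assay, putting 2-ethoxyphenyl in place of 4-propylphenyl on the amine nitrogen gives a 1.6-fold higher number from compound 1 to compound 3 (0.20 log units; within the scatter). The entering group carries an oxygen and a hydrogen-bond acceptor that the leaving group lacks, yet this step cannot be told apart from no change, so this swap on the aryl group does not measurably alter the read-out. Nothing available bears on the reason for this result.

From the compounds shown here alone, all three compounds carry a phenyl ring on this nitrogen, so it remains open whether a different kind of group there, such as a pyridine ring or a plain alkyl chain, would shift the number beyond the scatter. Going by these compounds, it also remains open whether a strongly charged substituent on the ring, such as a carboxylic acid or an amine, would do so.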